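The source may hold more compounds than are shown below. What is called first, only, known or untested is meant among the compounds shown, and "the series" means these compounds.

In a functional assay on NCI-H522 cells (Homo sapiens) for inhibition, read by sulforhodamine B assay, with a stated time of 48 h (on this read-out higher numbers stand for weaker inhibition of growth and lower numbers for stronger inhibition of growth), compound 1 `COc1cc(-c2nn(-c3cccc(NC(=O)c4cccc(C(F)(F)F)c4)c3)cc2-c2ccncc2)ccc1Cl` gives 3850 nM, and compound 2 `O=C(Nc1cccc(-n2cc(-c3ccncc3)c(-c3ccc(Cl)c(O)c3)n2)c1)Nc1cc(C(F)(F)F)cc(C(F)(F)F)c1` gives 2510 nM, the lowest of the two numbers shown, with compound 1 nearest and within the scatter. Compound 3 `COc1cc(-c2nn(-c3cccc(NC(=O)c4ccccc4)c3)cc2-c2ccncc2)ccc1Cl` reaches only a limit in this assay, > 100000 nM. Among the measured compounds shown here, the single measured step, an at least 25-fold higher number from compound 1 to compound 3 (1.41 log units; beyond the scatter), is large, and the compound 3 end sits at the limit of > 100000 nM in this assay, at which 1 of the 3 values shown sits.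

Compound 4 `O=C(Nc1cccc(-n2cc(-c3ccncc3)c(-c3ccc(Cl)c(O)c3)n2)c1)Nc1cccc(C(F)(F)F)c1` differs from compound 2 by hydrogen in place of trifluoromethyl on an aromatic carbon. The step from compound 1 to compound 3 is the only one bearing on it and points to a clearly weaker result; since one trifluoromethyl remains in compound 4, a smaller loss than an at least 25-fold higher number from compound 1 to compound 3 (1.41 log units; beyond the scatter) is expected, with a 4.8-fold higher number from compound 2 to compound 4 (0.68 log units; beyond the scatter) estimated. Compound 4 is therefore expected near 12000 nM, within 4000 nM to 50000 nM.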

Compound 4, concentration for total growth inhibition: 14500 nM
The estimate for compound 4 lay 1.2-fold (0.08 log units) below the measured number, and the stated range covers the measured number.
By their numbers in this assay, from the lowest: compounds 2 and 1 (each within the scatter of the next); then compound 4. At a limit, above all of these: compound 3.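

On the core of compound 2, hydrogen in place of trifluoromethyl also weakens growth inhibition, even with one trifluoromethyl group remaining on the ring, in this assay: a 5.8-fold higher number from compound 2 to compound 4 (0.76 log units; beyond the scatter). The size of this loss depends on the core: the same change on two cores in this assay, an at least 25-fold higher number (1.41 log units; beyond the scatter) from compound 1 to compound 3 and a 5.8-fold higher number (0.76 log units; beyond the scatter) from compound 2 to compound 4, at least 4.4-fold (0.65 log units) apart, beyond the scatter of two such steps

The value of compound 3, > 100000 nM, is a limit. Open, on these data alone, is how a nitrile or an amine at this place would compare with trifluoromethyl and with hydrogen. Also open, as far as these compounds go, is what loss of both trifluoromethyl groups from the core of compound 2 would give.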